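A few compounds are considered here, and "the series" means these few. Any claim that something is new, unique, unknown or untested is made for them only; others in the source may bear on it.

Measured so far:
compound 1 `CC1=C(C(=O)OC(C)(C)C)C(c2ccsc2)NC(=O)N1` — 1%
compound 2 `CC1=C(C(=O)OCC2CCC2)C(c2cccs2)NC(=O)N1` — 1%

In an assay on membranes from HeLa cells for displacement of a labelled ligand from adenosine receptor A3 (Homo sapiens), read by scintillation counting, with a stated time of 180 min, tested at 1 uM (a lower number here means less inhibition, a higher number more inhibition at the concentration tested (going by the name of the read-out)), compound 1 gives 1%. In this assay compound 2 gives 1%, level with compound 1 at the digits shown; the two lie within the usual scatter of each other, so nothing separates them. Going by the values given here, both sit at the floor of the read-out, and no step between measured compounds is recorded for this pair.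

Compound 3 `CC1=C(C(=O)OCC2CCC2)C(c2ccsc2)NC(=O)N1` has the same atoms as compound 2, joined differently: thiophen-3-yl in place of thiophen-2-yl on a saturated ring carbon. Compound 1 already carries thiophen-3-yl on a saturated ring carbon, differing from compound 3 elsewhere, and in this assay compound 1 stands no higher than compound 2. With both known values at the floor, no basis exists for a rise. For compound 3 no movement beyond the scatter is expected in this assay, a step of a number 1 percentage points higher from compound 2 to compound 3 (within the scatter). Compound 3 is estimated at 2%, ranging from -7% to 12%.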

Compound 3, a percentage reported as inhibition, at one concentration (the size of the read-out at that concentration, not a potency): 2%
Estimate against measurement, compound 3: no gap at the digits printed, within the range that was stated.
By their numbers in this assay, from the lowest: compounds 1, 2 and 3 (each within the scatter of the next).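

In this assay, going by these compounds alone, thiophen-3-yl in place of thiophen-2-yl on a saturated ring carbon gives a number 1 percentage points higher from compound 2 to compound 3 (within the scatter), the first direct reading of this position, and the point of attachment of the thiophene shows no effect here. Cyclobutylmethyl in place of tert-butyl on an oxygen next to a carbonyl group gives a number 1 percentage points higher from compound 1 to compound 3 (within the scatter), so the ester group, read with thiophen-3-yl held fixed, also shows no effect. Nothing available explains either result.

Going by these compounds, whether a phenyl ring at this position, or an amine or a carboxylic acid on the ester chain, would lift the inhibition clear of the scatter stays open. On these data alone, with all three compounds at the bottom of the read-out, it also stays open whether these two changes would matter in a compound showing clear inhibition.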